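A few compounds are considered here, and "the series" means these few. Any claim that something is new, unique, unknown or untested is made for them only; others in the source may bear on it.

Three compounds were measured in a functional assay on MCF7 cells (Homo sapiens) for cytotoxicity, read by MTT assay, with a stated time of 72 h; on this read-out lower numbers stand for stronger inhibition of growth and higher numbers for weaker inhibition of growth:

compound 1, `CS/C(=N\C(=O)c1ccco1)NC(=O)c1ccco1`, with 56100 nM;
compound 2, `O=C(/N=C(/NC(=O)c1cccs1)[Se]Cc1ccccc1)c1cccs1`, with 72500 nM;
compound 3, `CS/C(=N\C(=O)c1cccs1)NC(=O)c1cccs1`, with 44500 nM.

Compounds 2 and 3 differ by a group of 8 heavy atoms (7 carbon, 1 selenium; one six-membered aromatic ring of carbon only) in place of a group of 2 heavy atoms (1 carbon, 1 sulfur; no ring), on a carbon with a double bond to nitrogen. This change made a 1.6-fold higher number from compound 3 to compound 2 (0.21 log units; within the scatter). All three numbers lie within the usual scatter of one another, so no ordering among them can be read.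

Compound 4, `O=C(/N=C(/NC(=O)c1ccco1)[Se]Cc1ccccc1)c1ccco1`, is not yet measured. It differs from compound 1 by a group of 8 heavy atoms (7 carbon, 1 selenium; one six-membered aromatic ring of carbon only) in place of a group of 2 heavy atoms (1 carbon, 1 sulfur; no ring), on a carbon with a double bond to nitrogen. The difference between the core of compound 1 and the core of compound 3 is not broken down here. The places of the two changes are described in the same words, so this is the same change as that from compound 3 to compound 2.

Starting from compound 1, a step of a 1.4-fold higher number from compound 1 to compound 4 (0.15 log units; within the scatter) is expected in this assay, close to the earlier step, because compound 1 gives 56100 nM and the step of a 1.6-fold higher number from compound 3 to compound 2 (0.21 log units; within the scatter) stayed within the scatter. Compound 4 is therefore estimated at 80000 nM, likely between 35000 nM and 180000 nM.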

Compound 4, concentration for 50% growth inhibition: 8800 nM
Estimate against measurement, compound 4: 9.1-fold (0.96 log units) above, outside the stated range (below it).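

In this assay, putting the selenium-containing aromatic group in place of methylsulfanyl gave a 6.4-fold lower number from compound 1 to compound 4 (0.80 log units; beyond the scatter). The same change therefore did not carry over from one core to the other, and the two steps differ by more than the scatter: the same change on two cores in this assay, a 1.6-fold higher number (0.21 log units; within the scatter) from compound 3 to compound 2 and a 6.4-fold lower number (0.80 log units; beyond the scatter) from compound 1 to compound 4, 10-fold (1.02 log units) apart, beyond the scatter of two such steps. This shows that a step measured on one of these cores cannot simply be applied to the other, but it does not show why they differ, and two pairs give no rule for any further core.

As far as these compounds go, it remains open whether the selenium or the aromatic ring matters for the step on the core of compound 1. Methylselanyl or benzylsulfanyl in that place would separate the two.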